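Swapping the Aryl Group for Isopropyl on the Ring Nitrogen

A few compounds are considered here, and "the series" means these few. Any claim that something is new, unique, unknown or untested is made for them only; others in the source may bear on it.

Of the compounds shown here, three have been measured in an assay on HEK-293T cells for antagonist activity at vitamin D3 receptor (Homo sapiens), read by a luciferase reporter, with a stated time of 24 h; a lower number here means a stronger inhibitor, a higher number a weaker inhibitor. Compound 1 `CC(C)c1onc(-c2c(Cl)cccc2Cl)c1COc1ccc(-c2nc3ccc(C(=O)O)cc3n2C)cc1` gives 7150 nM, compound 2 `CCn1c(-c2ccc(OCc3c(-c4c(Cl)cccc4Cl)noc3C(C)C)cc2)nc2ccc(C(=O)O)cc21` gives 5760 nM, and compound 3 `CC(C)c1onc(-c2c(Cl)cccc2Cl)c1COc1ccc(-c2nc3ccc(C(=O)O)cc3n2-c2ccc(F)cc2)cc1` gives 2410 nM, the lowest of the three numbers and beyond the scatter from both others. Compound 4 `CC(C)c1onc(-c2c(Cl)cccc2Cl)c1COc1ccc(-c2nc3ccc(C(=O)O)cc3n2C(C)C)cc1` differs from compound 3 in one place: isopropyl in place of 4-fluorophenyl on an aromatic nitrogen. For the measured compounds named here, two measured steps bear on this change. Putting 4-fluorophenyl on the aromatic nitrogen gave a 3.0-fold lower number from compound 1 to compound 3 (0.47 log units; beyond the scatter) and a 2.4-fold lower number from compound 2 to compound 3 (0.38 log units; beyond the scatter). Isopropyl is a short branched chain, more like methyl or ethyl than like a ring, so the change is expected to undo much of that gain and raise the number. Compound 4 is therefore estimated at 5500 nM, with a range from 2500 nM to 12000 nM. That estimate means an expected 2.3-fold higher number from compound 3 to compound 4 (0.36 log units; beyond the scatter).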

Compound 4, half-maximal inhibitory concentration: 3550 nM
Compound 4: the middle estimate sits 1.5-fold (0.19 log units) above what was measured; the range from low to high includes it.
By their numbers in this assay, from the lowest: compounds 3, 4, 2 and 1 (each within the scatter of the next, the first and the last beyond it).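

The step to isopropyl gives (a 1.5-fold higher number from compound 3 to compound 4 (0.17 log units; within the scatter)), and the steps from the unbranched chains give (a 1.6-fold lower number from compound 2 to compound 4 (0.21 log units; within the scatter)) and (a 2.0-fold lower number from compound 1 to compound 4 (0.30 log units; within the scatter)), all within the scatter. At this aromatic nitrogen, then, isopropyl cannot be told apart from 4-fluorophenyl, ethyl or methyl, although 4-fluorophenyl does separate from the two unbranched chains, so a ring is not shown to be needed. Nothing available explains this result. Still open, going by these compounds, is whether phenyl without its fluorine, cyclopropyl or a longer chain such as butyl would separate from these groups beyond the scatter.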